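A few compounds are considered here, and "the series" means these few. Any claim that something is new, unique, unknown or untested is made for them only; others in the source may bear on it.

Measured compounds:
compound 1 `CCCc1nc(C(F)(F)F)ccc1CNC(=O)C(C)c1ccc(NS(C)(=O)=O)c(F)c1` gives 22.7 nM
compound 2 `CC(C(=O)NCc1ccc(C(F)(F)F)nc1C1=CCCCC1)c1ccc(NS(C)(=O)=O)c(F)c1` gives 0.7 nM
compound 3 `CC1C=C(c2nc(C(F)(F)F)ccc2CNC(=O)C(C)c2ccc(NS(C)(=O)=O)c(F)c2)CCC1` gives 0.2 nM

These three share one core and differ only in the group attached to one aromatic carbon. In an assay on CHO cells for antagonist activity at transient receptor potential cation channel subfamily V member 1 (Homo sapiens), read by FLIPR and calcium flux (on this read-out lower numbers stand for stronger inhibition and higher numbers for weaker inhibition), compound 1 stands with the highest number of the three, so it is the weakest inhibitor of the set. Replacing its propyl chain with a ring gave a large improvement: a 32-fold lower number from compound 1 to compound 2 (1.51 log units; beyond the scatter) and a 110-fold lower number from compound 1 to compound 3 (2.05 log units; beyond the scatter). Adding a methyl to that ring gave a further, smaller gain, a 3.5-fold lower number from compound 2 to compound 3 (0.54 log units; beyond the scatter).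

Compound 4 `CCC1CC=C(c2nc(C(F)(F)F)ccc2CNC(=O)C(C)c2ccc(NS(C)(=O)=O)c(F)c2)CC1` is not yet measured. It differs from compound 1 as follows: 4-ethylcyclohex-1-en-1-yl in place of propyl on an aromatic carbon

Both ring-bearing analogues bear on this change, since compound 4 also carries a six-membered non-aromatic ring at that position, here with an ethyl on the ring. A large lowering of the number, similar to that seen for compound 2 and compound 3, is therefore expected: a 57-fold lower number from compound 1 to compound 4 (1.75 log units; beyond the scatter). For compound 4 in this assay a value of 0.4 nM is estimated, within the range 0.1 nM to 1.5 nM.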

Compound 4, inhibition constant: 0.1 nM
Compound 4: middle estimate off by 4.0-fold (0.60 log units), on the high side; the measured number falls inside the stated range.
By their numbers in this assay, from the lowest: compounds 4 and 3 (each within the scatter of the next); then compound 2; then compound 1.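

In this assay, the 4-ethylcyclohex-1-en-1-yl ring extends the gain over the propyl chain, with (a 230-fold lower number from compound 1 to compound 4 (2.36 log units; beyond the scatter)). The ethyl group also counts for more than the bare ring does, with (a 7.0-fold lower number from compound 2 to compound 4 (0.85 log units; beyond the scatter)), so compound 3 and compound 4 both show that a small alkyl group on this ring lowers the number. Changing 3-methyl to 4-ethyl gives (a 2.0-fold lower number from compound 3 to compound 4 (0.30 log units; within the scatter)), which leaves these two compounds indistinguishable, and nothing available explains any of these steps.

Going by these compounds, since that last change alters both the size of the group and its place on the ring, the separate contribution of each stays unknown. A 4-methylcyclohex-1-en-1-yl group would separate the two, while a saturated cyclohexyl group would test whether the ring's double bond matters.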